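The source may hold more compounds than are shown below. What is called first, only, known or untested is meant among the compounds shown, and "the series" means these compounds.

Of the compounds shown here, two carry a measured value so far. Compound 1 `O=C(O)c1cc(-c2cccc(COc3ccc4c(=O)n(C5CCCC5)oc4c3)c2)ccc1Cl` gives in an assay on HEK293 cells for positive allosteric modulation of metabotropic glutamate receptor 2 (Rattus norvegicus), read by thallium flux (on this read-out lower numbers stand for smaller maximal responses and higher numbers for larger maximal responses), a maximal response of 64%. Compound 2 `O=C(O)c1cc(-c2cccc(COc3ccc4c(c3)CN(CC3CC3)C4=O)c2)ccc1Cl` gives in this assay 85.7%, the higher of the two numbers; the gap to compound 1 lies beyond the usual scatter of this read-out, so compound 2 stands clearly above it.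

Compound 3 `O=C(O)c1cc(-c2cccc(COc3ccc4c(c3)CN(c3ccccc3)C4=O)c2)ccc1Cl` is not yet measured. It differs from compound 2 in one place only: phenyl in place of cyclopropylmethyl on an amide-type nitrogen in a ring

Among the compounds with values here, no measured pair shows the effect of such an exchange on this nitrogen, so the size of the step cannot be read off from the numbers at hand and is worded as an expectation only. The step is expected to be a number 7.7 percentage points lower from compound 2 to compound 3 (within the scatter), a modest lowering that may well fall within the scatter. Compound 3 is expected to give 78% in this assay, with a likely range from 55% to 100%.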

Compound 3, largest response reached (Emax), in percent of the reference or control that the assay uses: 86.2%
Beside the measured number, compound 3's estimate is 8.2 percentage points below it; the range from low to high includes it.
By their numbers in this assay, from the lowest: compound 1; then compounds 2 and 3 (each within the scatter of the next).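

Within the data shown here, on the amide-type nitrogen in a ring, the exchange of cyclopropylmethyl for phenyl gives the first step that can be read at this position: in this assay it is a number 0.5 percentage points higher from compound 2 to compound 3 (within the scatter). Across this pair, the maximal response therefore shows no step beyond the scatter when a three-membered non-aromatic ring of carbon only gives way to a six-membered aromatic ring of carbon only, and the heavy-atom count of the group rises from 4 to 6. Nothing at hand bears on the reason for this result.

The compounds shown leave open whether the same level holds for a longer chain on this nitrogen, or for a group carrying an amine or a hydroxyl. They also leave open how a substituent such as fluorine on the phenyl would change the maximal response.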